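Branching the alkoxy chain of a chalcone core

The source may report more compounds than this note shows. Statements on the series, on what has been measured and on what is new or still open speak of the compounds shown alone.

Compounds measured so far in a functional assay on NCI-H23 cells (Homo sapiens) for antiproliferative activity, read by sulforhodamine B assay; a higher number here means a weaker inhibitor of growth, a lower number a stronger inhibitor of growth:
- compound 1 `CCCCCCOc1cccc(O)c1C(=O)/C=C/c1ccc(O)cc1` gives > 30000 nM; this is a limit of the assay, not a number.
- compound 2 `O=C(/C=C/c1ccc(O)cc1)c1c(O)cccc1OCc1ccccc1` gives > 30000 nM; this too is a limit of the assay.
- compound 3 `CC(C)CCCOc1cccc(O)c1C(=O)/C=C/c1ccc(O)cc1` gives 11400 nM.

Compound 1 stands at the weak end of what has been seen: its result is a limit, and the limit of > 30000 nM in this assay, at which 2 of the 3 values shown sit, shows that compound 2 sits at the same limit. Only compound 3 has a real number.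

Compound 4 `CC(C)CCOc1cccc(O)c1C(=O)/C=C/c1ccc(O)cc1` differs from compound 1 by isopropyl in place of butyl on a saturated chain carbon, two bonds along the chain from an oxygen on an aromatic ring. The measured step closest to this one is an at least 2.6-fold lower number from compound 1 to compound 3 (0.42 log units; beyond the scatter), where a branched chain of the same length replaced the straight one, and also an at least 2.6-fold lower number from compound 2 to compound 3 (0.42 log units; beyond the scatter), where a branched chain replaced a phenyl. Both steps move in the same direction, toward a lower number. Among the compounds with values here, the step to compound 4 is also a branching of the chain, though it shortens the chain by one carbon, and no measured pair speaks to that shortening.

The expectation is therefore a drop below the limit of modest size, roughly an at least 2.0-fold lower number from compound 1 to compound 4 (0.30 log units; that floor lies within the scatter). Compound 4 is estimated to give 15000 nM, with a range from 5000 nM to 40000 nM, and a real chance that only a limit is reported again.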

Compound 4, concentration for 50% growth inhibition: 12100 nM
Compound 4: middle estimate off by 1.2-fold (0.09 log units), on the high side; the range from low to high includes it.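

Swapping butyl for isopropyl at this place, two bonds along the chain from an oxygen on an aromatic ring, gives an at least 2.4-fold lower number from compound 1 to compound 4 (0.39 log units; beyond the scatter), and isobutyl in place of phenyl gives an at least 2.4-fold lower number from compound 2 to compound 4 (0.39 log units; beyond the scatter). Shortening the branched chain leaves this assay with no readable change, at a 1.1-fold higher number from compound 3 to compound 4 (0.03 log units; within the scatter), so a branched chain has now reached a measured number at two lengths, and those two lengths cannot be told apart here. The sizes of the steps from compound 1 and compound 2 are only floors, since both of those compounds sit at a limit: the limit of > 30000 nM in this assay, at which 2 of the 4 values shown sit.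

The compounds shown leave open whether branching itself accounts for the gain, as the hexyl chain of compound 1 is the only straight chain here and a straight pentyl chain would be needed to set against the branched chain of compound 4 at a matching length. They also leave open what a much shorter chain such as ethyl, or an amine at the end of the chain, would do at this place.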